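Swapping methyl for fluoro on compound 1

This account rests on a few compounds, and the source may have more. Where it says the series, first, only, none or still open, it means among the compounds named here.

Among the measured compounds shown here, in a functional assay (plasma) for inhibition, with Homo sapiens as the target (a lower number here means a stronger inhibitor, a higher number a weaker inhibitor), three related compounds have numbers so far. Compound 1 (`Cc1ccc(S(=O)(=O)N[C@H]2CC[C@H](O)[C@@H]2C/C=C\CCC(=O)O)cc1`) gives 2500 nM as the second highest of the three numbers. Compound 3 (`O=C(O)CCC/C=C\C[C@@H]1[C@H](O)CC[C@H]1NS(=O)(=O)c1ccc(Cl)cc1`) gives 2200 nM and so lies within the usual scatter of repeated measurements from compound 1, which means the two cannot be told apart. Compound 2 (`Cc1ccc(S(=O)(=O)N[C@H]2CC/C(=N\OC(c3ccccc3)c3ccccc3)[C@@H]2C/C=C\CCCC(=O)O)cc1`) gives 5600 nM and stands beyond the scatter from compound 1.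

Compound 4 (`O=C(O)CC/C=C\C[C@@H]1[C@@H](NS(=O)(=O)c2ccc(F)cc2)CC[C@@H]1O`) has not been measured yet. It differs from compound 1 by one swap (fluoro in place of methyl on an aromatic carbon), with fluoro in place of methyl on an aromatic carbon, para to a large group, so that 4-methylphenyl becomes 4-fluorophenyl. For the measured compounds named here, no two measured compounds differ in just one place, so the data give no direct guide to the size of such a step. With so little to go on, the expectation is for no change beyond the scatter in this assay, in either direction. The expected no change at the digits printed from compound 1 to compound 4 (within the scatter) is therefore small and remains a cautious guess. For compound 4 the estimated value is 2500 nM with 900 nM to 7000 nM as its expected range.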

Compound 4, half-maximal inhibitory concentration: 1600 nM
Compound 4: middle estimate off by 1.6-fold (0.19 log units), on the high side, and the stated range covers the measured number.
By their numbers in this assay, from the lowest: compounds 4, 3 and 1 (each within the scatter of the next); then compound 2.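

Swapping methyl for fluoro on the aromatic carbon para to a large group gives a 1.6-fold lower number from compound 1 to compound 4 (0.19 log units; within the scatter) in this assay, and this is the first step here in which only one place changes. At this position, then, 4-fluorophenyl and 4-methylphenyl cannot be told apart in this assay, so the position accepts this particular exchange of one heavy atom for another without a measurable shift. That finding rests on a single pair of compounds and says nothing about how the position responds to other groups, and no measurement at hand offers an explanation for this result.

Still open, from the compounds shown here alone, is whether a group of a different kind at this position, such as methoxy, trifluoromethyl, an amine or a longer alkyl chain, or simply hydrogen in place of the substituent, would move the number beyond the scatter. Also open, going by these compounds, is whether fluoro in place of methyl would give a similarly small step on the core of compound 2, whose number stands apart from those of the other compounds.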